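Two Halogenated Piperazines Point Toward a Dichloro Analogue

The source may report more compounds than this note shows. Statements on the series, on what has been measured and on what is new or still open speak of the compounds shown alone.

Measured so far:
- compound 1, `CC1CC(=O)N(CC(=O)N2CCN(c3cccc(Cl)c3)CC2)C1=O`: in a functional assay on the whole organism (strain CD1) with Mus musculus as the target, in the maximal electroshock model, with a stated time of 4 h (a higher number here means that more compound is needed for the effect, a lower number that less compound is needed), compound 1 gives 300 mg/kg
- compound 2, `CC1CC(=O)N(CC(=O)N2CCN(c3ccccc3F)CC2)C1=O`: in this assay compound 2 gives 300 mg/kg

Both compounds share one core, and in this assay they come out level: the step of no change at the digits printed from compound 1 to compound 2 (within the scatter) shows that swapping 3-chlorophenyl for 2-fluorophenyl on the ring nitrogen made no difference beyond the usual scatter of this kind of measurement. Compound 2 therefore stands level with compound 1 at the digits shown.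

Compound 3, `CC1CC(=O)N(CC(=O)N2CCN(c3ccc(Cl)c(Cl)c3)CC2)C1=O`, is the next step. Its change is 3,4-dichlorophenyl in place of 2-fluorophenyl on an amine nitrogen in a ring. Among the measured compounds shown here, no measured pair covers a 3,4-dichlorophenyl group, so only an indirect guide exists: the one measured step, no change at the digits printed from compound 1 to compound 2 (within the scatter), tells that moving from one halogenated phenyl group to another left the dose unchanged, and this is the sole evidence available. On that basis the expected step of no change at the digits printed from compound 2 to compound 3 (within the scatter) is none beyond the scatter. Compound 3 is thus estimated at 300 mg/kg, with a range from 100 mg/kg to 600 mg/kg.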

Compound 3, minimum effective dose: 100 mg/kg
Estimate against measurement, compound 3: 3.0-fold (0.48 log units) above; low and high end bracket the measured number.
By their numbers in this assay, from the lowest: compound 3; then compounds 1 and 2 (each within the scatter of the next).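

Putting a chloro group in place of a hydrogen on an aromatic carbon gives a 3.0-fold lower number from compound 1 to compound 3 (0.48 log units; beyond the scatter) in this assay and is the cleanest comparison here, since it is a single added atom on an otherwise unchanged molecule. It shows that the dose can respond to the phenyl group on the amine nitrogen in a ring, something the level pair of compound 1 and compound 2 gave no sign of. The larger swap of 3,4-dichlorophenyl in place of 2-fluorophenyl gives a 3.0-fold lower number from compound 2 to compound 3 (0.48 log units; beyond the scatter) and points the same way, but it changes both the kind and the number of halogens at once, so it cannot say which of the two matters, and nothing measured on these groups accounts for either step.

The compounds shown leave open whether the lower number depends on chlorine itself, or whether a methoxy or trifluoromethyl group placed on the same phenyl ring would do as much. They also leave open where a plain phenyl group, with no halogen on it, would stand against these three compounds.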